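Chloro for hydrogen at the benzylidene ring of compound 1

The compounds below may be only part of what the source reports. "The series", "measured", "known", "first", "only" and "open" are said of these compounds alone.

Measured compounds:
compound 1 `CN(C)CCn1cnnc1-c1cc(Oc2ccc(NC(=O)N/N=C/c3ccc(F)cc3)cc2F)ccn1`: 1370 nM
compound 2 `CN(C)CCn1cnnc1-c1cc(Oc2ccc(NC(=O)N/N=C/c3ccc(F)cc3F)cc2F)ccn1`: 960 nM
compound 3 `COc1cc(/C=N/NC(=O)Nc2ccc(Oc3ccnc(-c4nncn4CCN(C)C)c3)c(F)c2)cc(OC)c1OC`: 3620 nM

Three semicarbazones sharing one core were tested in a functional assay on HT-29 cells (Homo sapiens) for cytotoxicity, read by MTT assay, with a stated time of 72 h; a lower number here means a stronger inhibitor, a higher number a weaker inhibitor. Compound 1 gives 1370 nM, the second highest of the three numbers. Its nearest neighbour is compound 2, reached by a 1.4-fold lower number from compound 1 to compound 2 (0.15 log units; within the scatter), a step that stays within the scatter. The furthest is compound 3, which shows a 2.6-fold higher number from compound 1 to compound 3 (0.42 log units; beyond the scatter), and from compound 2 the same exchange reads a 3.8-fold higher number from compound 2 to compound 3 (0.58 log units; beyond the scatter).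

Compound 4 `CN(C)CCn1cnnc1-c1cc(Oc2ccc(NC(=O)N/N=C/c3ccc(F)cc3Cl)cc2F)ccn1` has not yet been measured. It differs from compound 1 by chloro in place of hydrogen on an aromatic carbon. Among the measured compounds shown here, the step that bears most directly on this is the one from compound 1 to compound 2, where a fluoro in place of hydrogen on the same aromatic carbon gave a 1.4-fold lower number from compound 1 to compound 2 (0.15 log units; within the scatter), a change within the scatter. For the measured compounds named here, no other measured pair places a substituent at that carbon. A chloro entering at that place is therefore expected to leave the number near that of compound 1, with at most a small move downward, that is a 1.4-fold lower number from compound 1 to compound 4 (0.14 log units; within the scatter). Compound 4 is estimated at 1000 nM, with a range from 400 nM to 2500 nM.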

Compound 4, half-maximal inhibitory concentration: 510 nM
Compound 4: middle estimate off by 2.0-fold (0.29 log units), on the high side; the range from low to high includes it.
By their numbers in this assay, from the lowest: compounds 4, 2 and 1 (each within the scatter of the next, the first and the last beyond it); then compound 3.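

In this assay, among the compounds shown here, chloro on this aromatic carbon, ortho to a large group, moves the number beyond the scatter (a 2.7-fold lower number from compound 1 to compound 4 (0.43 log units; beyond the scatter)), which the earlier fluoro at the same carbon did not do, so this is the first sign that the position responds to a substituent. Yet the direct exchange of fluoro for chloro stays within the scatter (a 1.9-fold lower number from compound 2 to compound 4 (0.27 log units; within the scatter)), so compound 2 and compound 4 cannot be told apart, and the result separates chloro from hydrogen rather than chloro from fluoro. The 2-chloro-4-fluorophenyl group also stands well apart from the 3,4,5-trimethoxyphenyl group (a 7.1-fold lower number from compound 3 to compound 4 (0.85 log units; beyond the scatter)), the widest step in the set, although no measurement shown accounts for any of these steps.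

The compounds shown leave open whether bromo, methyl or methoxy on this carbon would lower the number further, or whether a hydroxyl or an amine there would raise it. They also leave open whether chloro would give a similar step on a ring without the fluoro group, such as a plain phenyl.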